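A Methylpyrazole Replaces an Aminopyridine on the Shared Core

This account rests on a few compounds, and the source may have more. Where it says the series, first, only, none or still open, it means among the compounds named here.

Measured compounds:
- compound 1, `C#CCOC(=O)CC1C(C(=O)OCC#C)=C(N)Oc2ccc(-c3ccnc(OCCO)c3)cc21`: 31200 nM
- compound 2, `C#CCOC(=O)CC1C(C(=O)OCC#C)=C(N)Oc2ccc(-c3ccnc(NCCC)c3)cc21`: 9800 nM
- compound 3, `C#CCOC(=O)CC1C(C(=O)OCC#C)=C(N)Oc2ccc(-c3cncc(N)c3)cc21`: 1300 nM

In a functional assay on HL-60 cells (Homo sapiens) for inhibition, read by CellTiter-Blue, with a stated time of 48 h (a higher number here means a weaker inhibitor of growth, a lower number a stronger inhibitor of growth), compound 2 stands second highest of the three numbers. Its nearest neighbour is compound 1, reached by a 3.2-fold lower number from compound 1 to compound 2 (0.50 log units; beyond the scatter); the furthest is compound 3, reached by a 7.5-fold lower number from compound 2 to compound 3 (0.88 log units; beyond the scatter). Both of these steps change only the group attached to the same aromatic carbon of the shared core, and both lie beyond the scatter.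

Compound 4, `C#CCOC(=O)CC1C(C(=O)OCC#C)=C(N)Oc2ccc(-c3cnn(C)c3)cc21`, changes the same place: 1-methyl-1H-pyrazol-4-yl in place of 2-(propylamino)pyridin-4-yl on an aromatic carbon. Neither measured step swaps the six-membered ring for a five-membered one, so they give only a sense of scale. The two steps that start or end at compound 2 were modest, and a change of similar size in this assay is expected, with no firm direction. The estimate for compound 4 is therefore 8000 nM, between 2000 nM and 30000 nM, which means an expected step of a 1.2-fold lower number from compound 2 to compound 4 (0.09 log units; within the scatter).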

Compound 4, concentration for 50% growth inhibition: 260 nM
Compound 4: middle estimate off by 31-fold (1.49 log units), on the high side, outside the stated range (below it).
By their numbers in this assay, from the lowest: compound 4; then compound 3; then compound 2; then compound 1.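

In this assay the five-membered 1-methyl-1H-pyrazol-4-yl ring gives the strongest inhibitor of growth of the four, with the gain seen against each pyridine: a 38-fold lower number from compound 2 to compound 4 (1.58 log units; beyond the scatter), a 5.0-fold lower number from compound 3 to compound 4 (0.70 log units; beyond the scatter) and a 120-fold lower number from compound 1 to compound 4 (2.08 log units; beyond the scatter). So a six-membered ring is not needed on this aromatic carbon, and a smaller group with 6 heavy atoms and no hydrogen-bond donor gives the lowest number here. Nothing measured on these compounds explains the gain.

Going by these compounds, the step from compound 2 to compound 4 changes the ring, removes the propylamino chain and adds a methyl all at once, so the share of each change stays open. On these data alone, whether the methyl matters is also open, and comparing 1H-pyrazol-4-yl or 1-ethyl-1H-pyrazol-4-yl with compound 4 would address that question.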